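A few compounds are considered here, and "the series" means these few. Any claim that something is new, unique, unknown or untested is made for them only; others in the source may bear on it.

Measured so far, in a functional assay on K562 cells (Homo sapiens) for cytotoxicity, read by MTT assay, with a stated time of 72 h; a higher number here means a weaker inhibitor of growth, a lower number a stronger inhibitor of growth:
Compound 1, `CS/C(=N\C(=O)c1csc([N+](=O)[O-])c1)NC(=O)c1csc([N+](=O)[O-])c1`, gives 98700 nM.
Compound 2, `CS/C(=N\C(=O)c1ccco1)NC(=O)c1ccco1`, reaches only a limit of this assay, > 100000 nM, and no number.
Compound 3, `O=C(/N=C(/NC(=O)c1ccco1)[Se]Cc1ccccc1)c1ccco1`, gives 44200 nM.

Compounds 2 and 3 share a core and differ in one place: a group of 8 heavy atoms (7 carbon, 1 selenium; one six-membered aromatic ring of carbon only) in place of a group of 2 heavy atoms (1 carbon, 1 sulfur; no ring), on a carbon with a double bond to nitrogen. This change brings an at least 2.2-fold lower number from compound 2 to compound 3 (0.35 log units; beyond the scatter). Its size can only be given as a lower bound because the limit of > 100000 nM in this assay, at which 1 of the 3 values shown sits, is all that compound 2 shows.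

Compound 1 carries a different core from compound 2; the difference between the two cores is not broken down here. Compound 1 sits at the highest of the two plain numbers, with compound 3 nearest.

The unmeasured compound 4, `O=C(/N=C(/NC(=O)c1csc([N+](=O)[O-])c1)[Se]Cc1ccccc1)c1csc([N+](=O)[O-])c1`, is made from compound 1 by the same change: a group of 8 heavy atoms (7 carbon, 1 selenium; one six-membered aromatic ring of carbon only) in place of a group of 2 heavy atoms (1 carbon, 1 sulfur; no ring), on a carbon with a double bond to nitrogen. The surroundings of the change are the same in both pairs, so it is the same change on a different core.

Going by the values given here, the one measured example of this change lowers the number in this assay by at least a modest amount. Resting on that single step, compound 4 is expected to give a lower number than compound 1 in this assay, an estimated step of a 2.5-fold lower number from compound 1 to compound 4 (0.39 log units; beyond the scatter). For compound 4 the estimate is 40000 nM, expected to fall between 15000 nM and 100000 nM.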

Compound 4, concentration for total growth inhibition: 55800 nM
The estimate for compound 4 lay 1.4-fold (0.14 log units) below the measured number; the range from low to high includes it.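

On the core of compound 1, replacing the methylsulfanyl group with the larger group that carries selenium and a six-membered aromatic ring gives in this assay a 1.8-fold lower number from compound 1 to compound 4 (0.25 log units; within the scatter), so this step alone cannot be told apart from the ordinary variation between repeated measurements. Set beside the earlier step, the result shows at most a shared direction on these two cores, since only the earlier step lies beyond the scatter, and it does not show that the change brings a dependable gain on the core of compound 1 or a step of constant size: the same change on two cores in this assay, an at least 2.2-fold lower number (0.35 log units; beyond the scatter) from compound 2 to compound 3 and a 1.8-fold lower number (0.25 log units; within the scatter) from compound 1 to compound 4; the limit leaves it open whether they differ The earlier step has only a lower bound, because compound 2 gives no plain number, and so its full size stays unknown: the limit of > 100000 nM in this assay, at which 1 of the 4 values shown sits.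

As far as these compounds go, the change swaps the atom on the carbon and adds the ring in one move, so how a sulfur atom carrying the same ring or a selenium atom carrying only a methyl group would compare stays open, and the shares of selenium and of the ring cannot be separated. Also open, from the compounds shown here alone, is how an amine or a longer chain would behave at this same place, and whether the step would hold on a third core.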